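Expected clearance of a new dichlorophenyl sulfone

The compounds below may be only part of what the source reports. "The series", "measured", "known", "first", "only" and "open" are said of these compounds alone.

Three compounds have been measured in an ADME assay on microsomes from liver (Homo sapiens) for metabolic stability, tested at 2.5 uM; a lower number here means slower removal, a higher number faster removal of the compound:

compound 1, `O=S(=O)(c1cc(Cl)cc(Cl)c1)c1cnc2c(F)cccc2c1-c1cccc(Cl)c1`, gives 1.2 mL/min
compound 2, `O=S(=O)(c1cccc(F)c1)c1cnc2c(F)cccc2c1-c1cccc(Cl)c1`, gives 0.56 mL/min
compound 3, `O=S(=O)(c1cccc(F)c1)c1cnc2c(F)cccc2c1-c1cccc(F)c1`, gives 1.14 mL/min

Compound 3 differs from compound 2 only by fluoro in place of chloro on an aromatic carbon, and this change gave a 2.0-fold higher number from compound 2 to compound 3 (0.31 log units; beyond the scatter). Compound 4, `O=S(=O)(c1cc(Cl)cc(Cl)c1)c1cnc2c(F)cccc2c1-c1cccc(F)c1`, has not yet been measured; it differs from compound 3 by 3,5-dichlorophenyl in place of 3-fluorophenyl on a sulfonyl sulfur. The same change has been made once before, from compound 2 to compound 1, (3,5-dichlorophenyl in place of 3-fluorophenyl on a sulfonyl sulfur), at the same place, and there it gave a 2.1-fold higher number from compound 2 to compound 1 (0.33 log units; beyond the scatter). Among the compounds with values here, with only one earlier example, and with the two cores differing as described, the step is expected to be similar: from compound 3 to compound 4 a 2.1-fold higher number from compound 3 to compound 4 (0.32 log units; beyond the scatter) is expected, resting on a 2.1-fold higher number from compound 2 to compound 1 (0.33 log units; beyond the scatter). Compound 4 is therefore expected to give about 2.4 mL/min in this assay, most likely between 1.2 mL/min and 4.8 mL/min.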

Compound 4, intrinsic clearance in a liver preparation (reported as CLH), per the amount of preparation that the assay uses: 1.08 mL/min
Compound 4: the middle estimate sits 2.2-fold (0.35 log units) above what was measured, and the stated range ends above it.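

In this assay, 3,5-dichlorophenyl in place of 3-fluorophenyl on the sulfonyl sulfur gave a 1.1-fold lower number from compound 3 to compound 4 (0.02 log units; within the scatter), and fluoro in place of chloro on an aromatic carbon gave a 1.1-fold lower number from compound 1 to compound 4 (0.05 log units; within the scatter). These results neither establish that the effect of the sulfonyl change depends on the core nor show that it carries reliably from one core to the other: the same change on two cores in this assay, a 2.1-fold higher number (0.33 log units; beyond the scatter) from compound 2 to compound 1 and a 1.1-fold lower number (0.02 log units; within the scatter) from compound 3 to compound 4, 2.3-fold (0.35 log units) apart, within the scatter of two such steps The same caution applies to the change from chloro to fluoro: the same change on two cores in this assay, a 2.0-fold higher number (0.31 log units; beyond the scatter) from compound 2 to compound 3 and a 1.1-fold lower number (0.05 log units; within the scatter) from compound 1 to compound 4, 2.3-fold (0.35 log units) apart, within the scatter of two such steps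

The compounds shown carry only fluoro and chloro on their phenyl rings, so the effect of an amine or a carboxylic acid there remains open. From the compounds shown here alone, whether either change behaves the same way on other cores also remains open.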